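A dichlorophenyl swap in a series without measurable cell toxicity

This account rests on a few compounds, and the source may have more. Where it says the series, first, only, none or still open, it means among the compounds named here.

Compound 1 `Cc1cc(C)cc(-n2nncc2CN2C(=O)C3(C(C#N)=C(N)Oc4c3c3nc5ccccc5nc3c3ccccc43)c3ccccc32)c1` in an ADME assay on L02 cells (Homo sapiens) for antiproliferative activity, read by MTT assay, with a stated time of 48 h (on this read-out lower numbers stand for stronger inhibition and higher numbers for weaker inhibition), gives > 50000 nM, which is a limit of the assay rather than a number.
Compound 2 `Cc1ccc(-n2nncc2CN2C(=O)C3(C(C#N)=C(N)Oc4c3c3nc5ccccc5nc3c3ccccc43)c3ccccc32)c(C)c1` in this assay gives > 50000 nM, again a limit.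
Compound 3 `Cc1cccc(-n2nncc2CN2C(=O)C3(C(C#N)=C(N)Oc4c(N)cc5nc6ccccc6nc5c43)c3ccccc32)c1` in this assay gives > 50000 nM, also a limit.

Compound 3 therefore stands at the edge of what this assay can report, and it is not alone there: the limit of > 50000 nM in this assay, at which 3 of the 3 values shown sit. Within the data shown here, the only pair of measured compounds that differ in one place is compound 1 and compound 2, and their step reads a step that the two limits leave unreadable from compound 1 to compound 2, so it gives no measured size to lean on. The change studied here is 2,4-dichlorophenyl in place of 3-methylphenyl on an aromatic nitrogen, producing compound 4 `N#CC1=C(N)Oc2c(N)cc3nc4ccccc4nc3c2C12C(=O)N(Cc1cnnn1-c1ccc(Cl)cc1Cl)c1ccccc12`. Among the measured compounds shown here, no measured step touches this particular exchange, and the one step that exists cannot be read, so there is no basis for expecting a shift in either direction in this assay beyond the scatter of repeated measurements. Compound 4 is therefore expected to stay at the same limit, most likely again reported without a number. The estimated step from compound 3 to compound 4 in this assay is a step that the limit leaves unreadable from compound 3 to compound 4, that is, essentially none. On this basis compound 4 is estimated at 60000 nM, with a range from 20000 nM to 200000 nM.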

Compound 4, half-maximal inhibitory concentration: > 50000 nM
Compound 4 ended at the assay's limit; the forecaster's own chance of this, stated with the estimate: 80%; the middle value is on the limit's open side.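

Compound 3 and compound 4 both give a limit rather than a number, so no step can be read for 2,4-dichlorophenyl in place of 3-methylphenyl, and the whole set sits together: the limit of > 50000 nM in this assay, at which 4 of the 4 values shown sit.

The compounds shown leave open how far apart they truly lie in this assay, and whether any change to the shared core would give a readable number.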